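Replacing Pyridin-3-yl with 3,4-Difluorophenyl on Compound 1

The source may hold more compounds than are shown below. What is called first, only, known or untested is meant among the compounds shown, and "the series" means these compounds.

Measured so far in a functional assay on KB cells (Homo sapiens) for inhibition, with a stated time of 72 h; a lower number here means a stronger inhibitor, a higher number a weaker inhibitor:
compound 1 `COc1ccc(S(=O)(=O)N2CCc3cccc(-c4cccnc4)c32)cc1`: 95.9 nM
compound 2 `COc1ccc(S(=O)(=O)N2CCc3cccc(-c4ccc(C#N)cc4)c32)cc1`: 31.1 nM
compound 3 `COc1ccc(S(=O)(=O)N2CCc3cccc(-c4ccc(O)cc4)c32)cc1`: 129 nM

Compound 1 sits in the middle of these three numbers: its gap to compound 3 lies within the scatter, while a 3.1-fold lower number from compound 1 to compound 2 (0.49 log units; beyond the scatter) is beyond it. Compound 4 `COc1ccc(S(=O)(=O)N2CCc3cccc(-c4ccc(F)c(F)c4)c32)cc1` differs from compound 1 in one place: 3,4-difluorophenyl in place of pyridin-3-yl on an aromatic carbon. For the measured compounds named here, the steps that bear on this are a 3.1-fold lower number from compound 1 to compound 2 (0.49 log units; beyond the scatter) and a 1.3-fold higher number from compound 1 to compound 3 (0.13 log units; within the scatter), both exchanges of the same ring, and a 4.1-fold higher number from compound 2 to compound 3 (0.62 log units; beyond the scatter). Swapping the ring has moved the number by modest amounts in either direction, so a small step, probably downward, is expected in this assay for compound 4. The estimate for compound 4 is 60 nM, between 20 nM and 180 nM, meaning a 1.6-fold lower number from compound 1 to compound 4 (0.20 log units; within the scatter).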

Compound 4, half-maximal inhibitory concentration: 45 nM
Compound 4: middle estimate off by 1.3-fold (0.12 log units), on the high side; measured number inside the range.
By their numbers in this assay, from the lowest: compounds 2 and 4 (each within the scatter of the next); then compounds 1 and 3 (each within the scatter of the next).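

With 3,4-difluorophenyl on this aromatic carbon, the data show a 2.1-fold lower number from compound 1 to compound 4 (0.33 log units; beyond the scatter) and also a 2.9-fold lower number from compound 3 to compound 4 (0.46 log units; beyond the scatter), so the nitrogen of pyridin-3-yl and the hydroxy group are not needed for a low number. The comparison with the nitrile-bearing ring gives a 1.4-fold higher number from compound 2 to compound 4 (0.16 log units; within the scatter), which places two phenyl rings with quite different substituents level with each other. A low number at this position therefore does not depend on one particular substituent.

No measurement shown explains these steps. On these data alone, whether an amine or a carboxylic acid on the phenyl ring would keep the number this low remains open.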